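This account rests on a few compounds, and the source may have more. Where it says the series, first, only, none or still open, it means among the compounds named here.

Three compounds sharing one core have been examined in an assay on isolated protein (Mus musculus) for inhibition of IL15-IL15 receptor (Homo sapiens), read by resazurin assay, with stated times of 30 min and 2.5 days; a lower number here means a stronger inhibitor, a higher number a weaker inhibitor. Compound 2 `CC(C)Oc1ccc(NC(=O)CCCCCCCSc2nnc(Cc3nn(C)c(=O)c4ccccc34)n2C)cc1` gives 1100 nM and holds the lower of the two numbers obtained. Compound 1 `Cn1c(Cc2nn(C)c(=O)c3ccccc23)nnc1SCCCCCC(=O)Nc1ccc(Cl)cc1Cl` gives 4100 nM, a weaker result whose gap to compound 2 lies beyond the usual scatter. Compound 3 `COc1ccc(NC(=O)CSc2nnc(Cc3nn(C)c(=O)c4ccccc34)n2C)cc1` was reported as "not active" (no number reported), with no number attached. None of these three differs from another in a single place, so no isolated step can be read from them.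

Compound 4 `Cn1c(Cc2nn(C)c(=O)c3ccccc23)nnc1SCCCCCCCC(=O)Nc1ccc(F)cc1F` has not yet been measured. It departs from compound 2 through one change (2,4-difluorophenyl in place of 4-isopropoxyphenyl on an amide-type nitrogen). Among the measured compounds shown here, the only guidance is indirect: compound 1, whose ring on the amide-type nitrogen likewise carries two halogens, gives 4100 nM, though it also differs from compound 2 elsewhere. On that basis the step is expected to run toward a weaker inhibitor, of modest size, a 2.3-fold higher number from compound 2 to compound 4 (0.36 log units; beyond the scatter), and it may not exceed the scatter. Compound 4 is therefore estimated at 2500 nM, with a likely range from 800 nM to 8000 nM.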

Compound 4, half-maximal inhibitory concentration: 2300 nM
Compound 4: the middle estimate sits 1.1-fold (0.04 log units) above what was measured; low and high end bracket the measured number.
By their numbers in this assay, from the lowest: compound 2; then compounds 4 and 1 (each within the scatter of the next).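

In this assay, among the compounds shown here, 2,4-difluorophenyl in place of 4-isopropoxyphenyl on an amide-type nitrogen gives a 2.1-fold higher number from compound 2 to compound 4 (0.32 log units; beyond the scatter), the only single-place step available in this set, and it is modest. It shows that the group at this position can lose its oxygen, the one hydrogen-bond acceptor counted in 4-isopropoxyphenyl, and take two fluorines while a measurable number is kept. No supporting measurement bears on why the number moves.

On these data alone, it remains open whether the same step would hold for other groups on this nitrogen, such as an unsubstituted phenyl or a phenyl carrying an amine or a carboxylic acid. The effect of chain length cannot be read, since compounds 1 and 3 each differ from compound 2 in more than one place; a shorter or longer chain with the ring held fixed would separate it.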